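A few compounds are considered here, and "the series" means these few. Any claim that something is new, unique, unknown or untested is made for them only; others in the source may bear on it.

Measured set in a functional assay (aorta) with Rattus norvegicus as the target; a higher number here means a weaker inhibitor, a lower number a stronger inhibitor:
compound 1 `CCO/C(O)=C1\C(COCCn2nncc2C(N)=O)=NC(C)=C(C(=O)OC)C1c1cccc(Cl)c1Cl`, 15.9 nM
compound 2 `CCO/C(O)=C1\C(COCCn2nncc2C(N)=O)=NC(C)=C(C(=O)OC)C1c1ccccc1Cl`, 100 nM
compound 3 `CCO/C(O)=C1\C(COCCn2c(N)cnc2O)=NC(C)=C(C(=O)OC)C1c1ccccc1Cl`, 158 nM

Compound 1 has the lowest number of the three. Among the measured compounds shown here, the nearest of the other numbers is reached by a 6.3-fold higher number from compound 1 to compound 2 (0.80 log units; beyond the scatter), a step that rests only on hydrogen in place of chloro on an aromatic carbon; the furthest is that of compound 3, and that pair has no single-point step, the two values simply standing as given.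

The next compound, compound 4 `CCO/C(O)=C1\C(COCCN2CC(=O)N(C)C2=O)=NC(C)=C(C(=O)OC)C1c1cccc(Cl)c1Cl`, keeps both chloro substituents of compound 1 and differs from it only in the side chain: 3-methyl-2,4-dioxoimidazolidin-1-yl in place of 5-carbamoyl-1H-1,2,3-triazol-1-yl on a saturated chain carbon, two bonds along the chain from an oxygen on a saturated carbon

For the measured compounds named here, the one measured step that bears on a swap of the ring at this place is a 1.6-fold higher number from compound 2 to compound 3 (0.20 log units; within the scatter), a change of heterocycle on the same saturated chain carbon, and it stays within the scatter. Nothing measured here separates an aromatic ring from a non-aromatic one at that position, so the expectation for compound 4 is a step of similar size, at most a slight rise in the number, with a 1.6-fold higher number from compound 1 to compound 4 (0.20 log units; within the scatter) expected.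

On that basis compound 4 is estimated at 25 nM, with a range from 8 nM to 80 nM.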

Compound 4, half-maximal inhibitory concentration: 5.01 nM
Estimate against measurement, compound 4: 5.0-fold (0.70 log units) above; the whole stated range lies above it.
By their numbers in this assay, from the lowest: compound 4; then compound 1; then compounds 2 and 3 (each within the scatter of the next).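

In this assay, among the compounds shown here, the ring on the saturated chain carbon, two bonds along the chain from an oxygen on a saturated carbon, does affect the read-out: a 3.2-fold lower number from compound 1 to compound 4 (0.50 log units; beyond the scatter), whereas the only earlier change of ring at this place, a 1.6-fold higher number from compound 2 to compound 3 (0.20 log units; within the scatter), stayed within the scatter. An aromatic ring and a hydrogen-bond donor in this group are therefore not required, at least with both chloro substituents in place, as the non-aromatic 3-methyl-2,4-dioxoimidazolidin-1-yl, with 0 hydrogen-bond donors and 2 hydrogen-bond acceptors, gives the lower number in this single pair. No supporting data are available to explain this step.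

As far as these compounds go, it remains open whether 3-methyl-2,4-dioxoimidazolidin-1-yl gives a step of similar size on the core of compound 2, and whether the methyl or either carbonyl of that ring accounts for the step. Also open, from the compounds shown here alone, is how a side chain ending in a simple amine or a carboxylic acid, or a longer chain in place of the ethoxy link, would compare with compound 4.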